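A Longer Chain on the Ring Nitrogen

The compounds below may be only part of what the source reports. "The series", "measured", "known", "first", "only" and "open" are said of these compounds alone.

Going by the values given here, compound 1 `NC(=O)c1c(NC(=O)Nc2ccc(Cl)cc2)sc2c1CCN(C1CCOCC1)C2` is the only compound here with a measured number. In a functional assay (strain AB) with Danio rerio as the target, read by microscopy, with a stated time of 1 h (on this read-out lower numbers stand for an effect already at smaller amounts and higher numbers for an effect only at larger amounts of compound), compound 1 gives 2830 nM. Compound 2 `CCN1CCc2c(sc(NC(=O)C3(c4ccc(Cl)cc4)CC3)c2C(N)=O)C1` gives > 25000 nM in this assay, which is a limit of the assay and not a number (the limit of > 25000 nM in this assay, at which 1 of the 2 values shown sits). Compound 3 `CC(C)(C)OC(=O)CCCCN1CCc2c(sc(NC(=O)Nc3ccc(Cl)cc3)c2C(N)=O)C1` differs from compound 1 in one place: 4-(tert-butoxycarbonyl)butyl in place of oxan-4-yl on an amine nitrogen in a ring. Among the compounds with values here, no measured step covers a change of this kind, so the expected step of a 1.4-fold higher number from compound 1 to compound 3 (0.15 log units; within the scatter) is small, leaning slightly toward a weaker effect but within the scatter. Compound 3 is estimated at 4000 nM, with a likely range from 1200 nM to 15000 nM.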

Compound 3, half-maximal effective concentration: 710 nM
Beside the measured number, compound 3's estimate is 5.6-fold (0.75 log units) above it; the whole stated range lies above it.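

On the amine nitrogen in the ring, 4-(tert-butoxycarbonyl)butyl in place of oxan-4-yl gives a 4.0-fold lower number from compound 1 to compound 3 (0.60 log units; beyond the scatter) in this assay. This position therefore accepts a larger group with no ring, and the effect appears at smaller amounts of compound. Nothing shown explains why this change helps.

Going by these compounds, whether the gain belongs to the ester or to the chain stays open. A carboxylic acid at the end of the same chain, or a plain alkyl chain with no ester, would help separate the two.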